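The compounds below may be only part of what the source reports. "The series", "measured", "known", "first", "only" and "open" are said of these compounds alone.

Of the compounds shown here, two have so far been measured in an ADME assay on stomach for pharmacokinetics, in simulated gastric fluid; on this read-out higher numbers stand for a longer-lived compound and lower numbers for a shorter-lived compound. Compound 1 `CCOc1cc(NC(=O)C2(NC(=O)c3ccc4c(C5CCCC5)c(-c5ncc(Cl)cn5)n(C)c4c3)CCC2)ccc1/C=C/C(=O)N[C@@H](CCCNC(=N)N)C(N)=O` gives 0.467 h in this assay, and compound 2 `CCOc1cc(NC(=O)C2(NC(=O)c3ccc4c(C5CCCC5)c(-c5ncc(Cl)cn5)n(C)c4c3)CCC2)ccc1/C=C/C(=O)OCOP(=O)(O)O` gives 1.3 h. Among the measured compounds shown here, compound 2 thus holds the higher of the two numbers, and the only measured step, a 2.8-fold higher number from compound 1 to compound 2 (0.44 log units; beyond the scatter), separates them; this step exchanged the group attached to the carbonyl carbon at one end of the molecule.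

Compound 3 `CCOC(=O)/C=C/c1ccc(NC(=O)C2(NC(=O)c3ccc4c(C5CCCC5)c(-c5ncc(Cl)cn5)n(C)c4c3)CCC2)cc1OCC` has not yet been measured. It differs from compound 2 in one carbon atom in place of a group of 5 heavy atoms (4 oxygen, 1 phosphorus; no ring), on a saturated chain carbon bound to an oxygen next to a carbonyl group, so the same end of the molecule is altered again, though in a different way from the measured step. For the measured compounds named here, that single step from compound 1 to compound 2 is the only guide here, and it bears on the new change only loosely, since it swapped a different group at a nearby position. It showed a modest rise when the end group was changed, so a change of similar or smaller size, and most likely a longer half-life rather than a shorter one, is expected. Compound 3 is estimated to give 2 h, with a likely range from 0.8 h to 5 h. This corresponds to an expected step of a 1.5-fold higher number from compound 2 to compound 3 (0.19 log units; within the scatter).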

Compound 3, half-life: 0.333 h
Estimate against measurement, compound 3: 6.0-fold (0.78 log units) above; measured number below the stated range.
By their numbers in this assay, from the lowest: compounds 3 and 1 (each within the scatter of the next); then compound 2.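

In this assay, methyl in place of the group of 5 heavy atoms (4 oxygen, 1 phosphorus), on a saturated chain carbon bound to an oxygen next to a carbonyl group, gives a 3.9-fold lower number from compound 2 to compound 3 (0.59 log units; beyond the scatter); the higher number of compound 2 therefore does not carry over to every replacement at this end of the molecule, and it is lost when the phosphorus-containing group goes. The second comparison, a 1.4-fold lower number from compound 1 to compound 3 (0.15 log units; within the scatter), puts the end group of compound 3 and a group of 12 heavy atoms, both on a carbonyl carbon, within the scatter of each other, while compound 2, with its group of 7 heavy atoms, stands beyond the scatter of both, so across these three compounds the number does not follow the size of the end group. No supporting measurement is available to explain why compound 2 stands apart.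

These compounds do not separate the part played by the phosphorus from that of the oxygen atoms around it. A carboxylic acid on the same carbonyl carbon, or a longer chain in place of the methyl, would show how far the half-life depends on this group.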